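The source may report more compounds than this note shows. Statements on the series, on what has been measured and on what is new or still open speak of the compounds shown alone.

Compound 3 `COC(=O)c1ccc(-c2cnc(C(=O)CCc3ccc(-c4ccccc4)cc3)o2)cn1` gives the lowest number of the three measured in an assay for inhibition of Fatty-acid amide hydrolase 1 (Rattus norvegicus) (a lower number here means a stronger inhibitor, a higher number a weaker inhibitor), with 0.6 nM. Compound 2 `NC(=O)c1ccc(-c2cnc(C(=O)CCc3ccc(-c4ccccc4)cc3)o2)nc1` gives 1.3 nM in this assay, and compound 1 `N#Cc1cccc(-c2cnc(C(=O)CCc3ccc(-c4ccccc4)cc3)o2)n1` gives 2.9 nM. Among the measured steps, a 4.8-fold lower number from compound 1 to compound 3 (0.68 log units; beyond the scatter) is the largest, while a 2.2-fold lower number from compound 1 to compound 2 (0.35 log units; beyond the scatter) and a 2.2-fold lower number from compound 2 to compound 3 (0.34 log units; beyond the scatter) are each of the same modest size. Compound 4 `O=C(O)c1ccc(-c2cnc(C(=O)CCc3ccc(-c4ccccc4)cc3)o2)cn1` differs from compound 3 in one place: hydrogen in place of methyl on an oxygen next to a carbonyl group. None of the three measured steps concerns a change of this kind; each of them exchanges the whole group on the aromatic carbon for another, whereas here the rest of compound 3 is kept and only the methyl leaves. With nothing in the measured set that directly bears on it, the step is expected to be modest and toward a higher number, so compound 4 is expected at 6 nM, with a range from 1.5 nM to 30 nM. That estimate means a 10-fold higher number from compound 3 to compound 4 (1.00 log units; beyond the scatter), a step expected to exceed the scatter.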

Compound 4, inhibition constant: 44 nM
Compound 4: middle estimate off by 7.3-fold (0.87 log units), on the low side; measured number outside the range, above it.
By their numbers in this assay, from the lowest: compound 3; then compound 2; then compound 1; then compound 4.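

In this assay, among the compounds shown here, the ester of compound 3 proves far from interchangeable with its acid: with only the methyl replaced by hydrogen on the oxygen next to the carbonyl group, the result is a 73-fold higher number from compound 3 to compound 4 (1.87 log units; beyond the scatter), a larger step than any among the earlier compounds, even though each of those exchanged a whole group. The 6-carboxypyridin-3-yl group also separates compound 4 from the remaining two, with a 34-fold higher number from compound 2 to compound 4 (1.53 log units; beyond the scatter) and a 15-fold higher number from compound 1 to compound 4 (1.18 log units; beyond the scatter), making compound 4 the weakest of the four. Nothing available here explains this loss.

The compounds shown leave open whether the loss is specific to the carboxylic acid. An ethoxycarbonyl or hydroxymethyl group on the same pyridine could show whether the number stays near that of compound 3 or moves toward that of compound 4.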